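A Chlorine Step Carried from One Core to Another

A few compounds are considered here, and "the series" means these few. Any claim that something is new, unique, unknown or untested is made for them only; others in the source may bear on it.

Of the compounds shown here, three have been measured so far in a functional assay on the whole organism (Hindlimb, strain albino) with Mus musculus as the target, in the maximal electroshock model, with a stated time of 0.5 h; on this read-out higher numbers stand for an effect only at larger amounts of compound and lower numbers for an effect already at smaller amounts. Compound 1 `Cc1ccc2nc(NC(=O)/C=C/c3ccccc3)sc2c1` gives 380 umol/kg. Compound 3 `Cc1ccc2nc(NC(=O)/C=C/c3ccc(Cl)cc3)sc2c1` differs from compound 1 by a single change, (chloro in place of hydrogen on an aromatic carbon); compound 3 gives 152 umol/kg, so that the step of a 2.5-fold lower number from compound 1 to compound 3 (0.40 log units; beyond the scatter) is the only measured effect of adding a chlorine in this series. Compound 2 `O=C(/C=C/OC1=CC=C1)Nc1nc2ccccc2s1` rests on a different core; how the two cores differ is not broken down here. In this assay compound 2 gives 781 umol/kg, the highest of the three numbers.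

Compound 4 `O=C(/C=C/OC1=CC=C1)Nc1nc2ccc(Cl)cc2s1` is compound 2 with the change (chloro in place of hydrogen on an aromatic carbon). This is the same kind of change as that from compound 1 to compound 3, but not the same: in compound 3 the chlorine sits para to a large group on the phenyl, whereas in compound 4 it sits meta to a fused ring and para to a fused ring, on the core itself. Because the step of a 2.5-fold lower number from compound 1 to compound 3 (0.40 log units; beyond the scatter) was modest and the place now differs, a smaller improvement is expected, a 1.7-fold lower number from compound 2 to compound 4 (0.24 log units; within the scatter). Compound 4 is therefore estimated to give 450 umol/kg, with a likely range from 200 umol/kg to 1000 umol/kg.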

Compound 4, dose for half-maximal effect: 544 umol/kg
Compound 4: the middle estimate sits 1.2-fold (0.08 log units) below what was measured; measured number inside the range.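

In this assay, the chloro group on the core of compound 2 gives a 1.4-fold lower number from compound 2 to compound 4 (0.16 log units; within the scatter), so on this core the change cannot be told apart from the usual spread of repeated measurements. Set beside the earlier step, the new one does not differ from it by more than the scatter of two such steps allows: the same change on two cores in this assay, a 2.5-fold lower number (0.40 log units; beyond the scatter) from compound 1 to compound 3 and a 1.4-fold lower number (0.16 log units; within the scatter) from compound 2 to compound 4, 1.7-fold (0.24 log units) apart, within the scatter of two such steps. Among these compounds, this shows that the two results are compatible with a shared effect of the chlorine, but it does not show that the effect carries from one core to another, as only one of the two steps lies beyond the scatter, and the chlorine stands on the phenyl in compound 3 and on the fused system in compound 4.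

The compounds shown leave open whether a fluoro, methoxy or amino group in the place of the chlorine would behave in the same way on either core. They also leave open how a chlorine elsewhere on the fused system of compound 4 would read.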